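Ethyl amide in a 17-alpha-hydroxylase inhibitor series

The source may report more compounds than this note shows. Statements on the series, on what has been measured and on what is new or still open speak of the compounds shown alone.

Compound 2 `CC(C)C(O)(c1ccc2cc(C(N)=O)ccc2c1)c1c[nH]cn1` gives 30 nM in an assay on isolated protein for inhibition of steroid 17-alpha-hydroxylase/17,20 lyase (Homo sapiens) (a lower number here means a stronger inhibitor, a higher number a weaker inhibitor), the lowest of the two numbers at hand, although its nearest neighbour, compound 1 `CCCNC(=O)c1ccc2cc(C(O)(c3c[nH]cn3)C(C)C)ccc2c1`, with 38 nM, lies within the scatter of it. Compound 3 `CCNC(=O)c1ccc2cc(C(O)(c3c[nH]cn3)C(C)C)ccc2c1` differs from compound 2 by ethyl in place of hydrogen on an amide-type nitrogen. Among the compounds with values here, the only measured step bearing on this change sits on the same amide nitrogen: a 1.3-fold lower number from compound 1 to compound 2 (0.10 log units; within the scatter). Because a 1.3-fold lower number from compound 1 to compound 2 (0.10 log units; within the scatter) stayed within the scatter, the expected step is a 1.1-fold higher number from compound 2 to compound 3 (0.04 log units; within the scatter), nothing beyond the scatter. Compound 3 is therefore estimated at 33 nM, within 15 nM to 75 nM.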

Compound 3, half-maximal inhibitory concentration: 46 nM
Compound 3: middle estimate off by 1.4-fold (0.14 log units), on the low side; the range from low to high includes it.
By their numbers in this assay, from the lowest: compounds 2, 1 and 3 (each within the scatter of the next).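

In this assay, ethyl on the amide-type nitrogen gives a 1.5-fold higher number from compound 2 to compound 3 (0.19 log units; within the scatter), and shortening propyl to ethyl gives a 1.2-fold higher number from compound 1 to compound 3 (0.08 log units; within the scatter). With hydrogen, ethyl and propyl all on this nitrogen, none of the steps among compounds 1, 2 and 3 lies beyond the scatter, so no order can be drawn among them. No evidence at hand bears on these numbers.

On these data alone, whether a longer chain or a branched chain such as isopropyl on this nitrogen would move the number beyond the scatter remains open. So does the effect of a carboxylic acid in place of the amide.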